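Swapping the aryl group on the core of compound 2

The compounds below may be only part of what the source reports. "The series", "measured", "known", "first", "only" and "open" are said of these compounds alone.

Compound 2, with the structure `Cc1ccc(-c2noc(-c3ccc(C(=O)C(F)(F)F)s3)n2)cc1`, gives 860 nM in an assay on isolated protein for inhibition of protein deacetylase HDAC6 (Homo sapiens) (a higher number here means a weaker inhibitor, a lower number a stronger inhibitor), the lowest of the three numbers measured. Compound 3, `O=C(c1ccc(-c2ncc(-c3ccccc3)s2)s1)C(F)(F)F`, gives 1350 nM, which lies within the scatter of compound 2. Compound 1, `O=C(c1ccc(-c2nc(-c3ccc(C(F)(F)F)cc3)no2)s1)C(F)(F)F`, gives 11000 nM, far above it. Among the compounds with values here, the one measured step, a 13-fold lower number from compound 1 to compound 2 (1.11 log units; beyond the scatter), shows that the group on the six-membered aromatic ring of carbon only matters strongly.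

Compound 4, `O=C(c1ccc(-c2nc(-c3ccccn3)no2)s1)C(F)(F)F`, has not been measured. It differs from compound 2 by pyridin-2-yl in place of 4-methylphenyl on an aromatic carbon. Within the data shown here, no measured step concerns this exact change, so the step from compound 1 to compound 2 is the only guide: it shows that this part of the molecule is sensitive. The change to compound 4 is therefore expected to move the number, most likely upward, and the step of a 4.7-fold higher number from compound 2 to compound 4 (0.67 log units; beyond the scatter) is the estimate for it. Compound 4 is expected to give about 4000 nM, within a range from 1200 nM to 13000 nM.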

Compound 4, half-maximal inhibitory concentration: 500 nM
Estimate against measurement, compound 4: 8.0-fold (0.90 log units) above; the whole stated range lies above it.
By their numbers in this assay, from the lowest: compounds 4, 2 and 3 (each within the scatter of the next, the first and the last beyond it); then compound 1.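

In this assay, the step of a 1.7-fold lower number from compound 2 to compound 4 (0.24 log units; within the scatter) lies within the scatter, so pyridin-2-yl in place of 4-methylphenyl leaves the two compounds indistinguishable. This aromatic carbon of the core is therefore not sensitive to every change: the step of a 13-fold lower number from compound 1 to compound 2 (1.11 log units; beyond the scatter) shows a large effect from the group on the six-membered ring, yet exchanging that substituted ring for a ring holding a nitrogen atom has no effect beyond the scatter. No evidence is available to explain this difference between the two changes.

Compound 4 loses the methyl and gains the ring nitrogen in a single change, so a plain phenyl on this same core would be needed to separate the two. Also open, going by these compounds, is how this carbon would respond to pyridin-4-yl, or to a group without a ring, such as an amine or a carboxylic acid.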